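The source may report more compounds than this note shows. Statements on the series, on what has been measured and on what is new or still open speak of the compounds shown alone.

Measured compounds in the series:

- compound 1, `Nc1ccccc1NC(=O)c1ccc(CSC(=S)N2CCN(Cc3ccccn3)CC2)cc1`: 20.7%
- compound 2, `CN(C(=S)SCc1ccc(C(=O)Nc2ccccc2N)cc1)c1cccnc1`: 26.5%
- compound 3, `CC1CCCCN1C(=S)SCc1ccc(C(=O)Nc2ccccc2N)cc1`: 42.5%

All three share one core and differ in the group attached to the thiocarbonyl carbon. In a functional assay on A-375 cells (Homo sapiens) for antiproliferative activity, read by CCK-8 assay, with a stated time of 72 h, tested at 2 uM (a higher number here means a stronger effect of the compound at the concentration tested, a lower number a weaker effect), compound 1 gives the lowest of the three numbers; its gap to compound 2 is within the scatter, so the two cannot be ordered, while compound 3 sits beyond the scatter above it.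

Going by the values given here, the one step that can be sized here is a number 16 percentage points higher from compound 2 to compound 3 (beyond the scatter), a modest gain when a saturated ring amine replaces an aryl-bearing open-chain amine on the thiocarbonyl carbon. Among the compounds with values here, it tells only that changes at this position can move this assay by a modest amount; it does not involve the ring nitrogen that is changed next.

Compound 4, `N#Cc1ccc(N2CCN(C(=S)SCc3ccc(C(=O)Nc4ccccc4N)cc3)CC2)cc1`, is still unmeasured. The change from compound 1 is 4-cyanophenyl in place of (pyridin-2-yl)methyl on an amine nitrogen in a ring. Within the data shown here, no measured pair varies this position, so the direction of the step is unsupported by data, and the single relevant step above was only modest. A step near zero, within the scatter, is therefore expected, with a range wide enough for a modest move either way.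

The expected value of compound 4 in this assay is 26%, between 10% and 45%, which corresponds to an expected step of a number 5.3 percentage points higher from compound 1 to compound 4 (within the scatter).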

Compound 4, a percentage reported as inhibition, at one concentration (the size of the read-out at that concentration, not a potency): 41.4%
For compound 4 the middle estimate is 15.4 percentage points below the measured one; the measured number falls inside the stated range.
By their numbers in this assay, from the lowest: compounds 1 and 2 (each within the scatter of the next); then compounds 4 and 3 (each within the scatter of the next).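

The amine nitrogen in the six-membered non-aromatic ring is a position that can move this assay: putting 4-cyanophenyl in place of (pyridin-2-yl)methyl there gives a number 20.7 percentage points higher from compound 1 to compound 4 (beyond the scatter) as the result of this single change. Going by these compounds alone, the earlier compounds sized only a step on the thiocarbonyl carbon, a number 16 percentage points higher from compound 2 to compound 3 (beyond the scatter) for that exchange, so this is the first sign that a change within the same ring amine, with the thiocarbonyl link and the rest of the shared core kept, can also produce a modest step. The step has a direction but no explanation, as nothing available here bears on why the number rises.

The exchange alters several features at once, including the linking carbon, the ring nitrogen of the pyridine and the nitrile, so the compounds shown leave open which of these carries the step. Phenyl, pyridin-2-yl and 4-cyanobenzyl on the same nitrogen would separate those features, while a carboxylic acid or a primary amine in place of the nitrile would test whether that part of the group matters.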